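Swapping the sulfur substituent in a thioether enone series

The source may report more compounds than this note shows. Statements on the series, on what has been measured and on what is new or still open speak of the compounds shown alone.

Compound 1 `Cc1ccc(S/C(=C/c2sccc2C)C(=O)c2ccc(Cl)cc2)cc1` is tested in a functional assay on DU-145 cells (Homo sapiens) for inhibition, read by trypan blue exclusion, with a stated time of 96 h (on this read-out lower numbers stand for stronger inhibition of growth and higher numbers for weaker inhibition of growth), and gives 50000 nM, the highest of the three numbers shown. Compound 2 `Cc1ccc(S/C(=C/c2ccc[nH]2)C(=O)c2ccc(Cl)cc2)cc1` gives 10000 nM and compound 3 `COc1ccccc1/C=C(/Sc1ccc(C)cc1)C(=O)c1ccc(Cl)cc1` gives 25000 nM, so that a 5.0-fold lower number from compound 1 to compound 2 (0.70 log units; beyond the scatter) and a 2.0-fold lower number from compound 1 to compound 3 (0.30 log units; within the scatter). Compound 4 `Cc1ccsc1/C=C(/SCc1ccc(F)cc1)C(=O)c1ccc(Cl)cc1` differs from compound 1 in one place: 4-fluorobenzyl in place of 4-methylphenyl on a sulfur. The measured steps all exchange the group on a double-bonded chain carbon, while the group on the sulfur is left untouched in every one of them, so none of them bears directly on this change. With no guidance from the data, the expected step of no change at the digits printed from compound 1 to compound 4 (within the scatter) is none beyond the scatter. Compound 4 is therefore estimated at 50000 nM, with a range from 15000 nM to 150000 nM.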

Compound 4, concentration for 50% growth inhibition: 50000 nM
For compound 4 middle estimate and measured number coincide at the digits printed; the measured number falls inside the stated range.
By their numbers in this assay, from the lowest: compound 2; then compounds 3, 1 and 4 (each within the scatter of the next).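

In this assay, putting 4-fluorobenzyl in place of 4-methylphenyl on a sulfur gives no change at the digits printed from compound 1 to compound 4 (within the scatter), the only step shown at this position. Unlike the exchange of 3-methylthiophen-2-yl for 1H-pyrrol-2-yl on the double-bonded chain carbon, this change leaves the number within the scatter. Nothing shown accounts for this result.

This single pair leaves open whether a group such as a carboxylic acid or an aminoethyl chain on the sulfur would shift the number. It also leaves open whether 4-fluorobenzyl would behave the same way with the 1H-pyrrol-2-yl group of compound 2.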